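Ester group variation: from compound 3 to compound 4

A few compounds are considered here, and "the series" means these few. Any claim that something is new, unique, unknown or untested is made for them only; others in the source may bear on it.

Three esters of one shared core have been measured in an assay on HEK-Blue hTLR2 cells for agonist activity at Toll-like receptor 2 (Homo sapiens), with a stated time of 24 h; a lower number here means that less compound is needed, a higher number that more compound is needed for the effect. Compound 1 `COC(=O)c1c(NC(=S)Nc2cccc3ccccc23)sc2c1CCC2` gives 3570 nM, compound 2 `CCCOC(=O)c1c(NC(=S)Nc2cccc3ccccc23)sc2c1CCC2` gives 820 nM, and compound 3 `CC(C)OC(=O)c1c(NC(=S)Nc2cccc3ccccc23)sc2c1CCC2` gives 180 nM. Compound 3 holds the lowest number of the three: the step of a 20-fold lower number from compound 1 to compound 3 (1.30 log units; beyond the scatter) is large, and the step of a 4.6-fold lower number from compound 2 to compound 3 (0.66 log units; beyond the scatter) is modest, as is a 4.4-fold lower number from compound 1 to compound 2 (0.64 log units; beyond the scatter).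

Compound 4 `CC(C)COC(=O)c1c(NC(=S)Nc2cccc3ccccc23)sc2c1CCC2` is not yet measured. It differs from compound 3 by isobutyl in place of isopropyl on an oxygen next to a carbonyl group. Among the measured compounds shown here, no measured step repeats this exact change. For the measured compounds named here, the steps that bear on it all enlarge the ester group from methyl, and each lowered the number; yet the step from propyl to isopropyl shows that one more carbon does not itself fix the direction. On that basis the step of a 1.7-fold higher number from compound 3 to compound 4 (0.22 log units; within the scatter) is expected to be small, possibly a modest rise. Compound 4 is therefore estimated at 300 nM in this assay, within a range of 100 nM to 900 nM.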

Compound 4, half-maximal effective concentration: 28200 nM
Compound 4: middle estimate off by 94-fold (1.97 log units), on the low side; measured number outside the range, above it.
By their numbers in this assay, from the lowest: compound 3; then compound 2; then compound 1; then compound 4.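

In this assay, the place on an oxygen next to a carbonyl group proves far less forgiving than the first three esters suggested: a 160-fold higher number from compound 3 to compound 4 (2.19 log units; beyond the scatter) shows that enlarging the group can also raise the number sharply. Compound 4 breaks the earlier pattern of lower numbers on moving up from methyl, with a 7.9-fold higher number from compound 1 to compound 4 (0.90 log units; beyond the scatter) and a 34-fold higher number from compound 2 to compound 4 (1.54 log units; beyond the scatter), so isobutyl ranks behind even the methyl ester of compound 1. No accompanying data explain why isopropyl and isobutyl separate so widely.

On these data alone, whether the rise is particular to isobutyl or extends to a longer chain such as pentyl, or to a tert-butyl ester, remains open. Also open, as far as these compounds go, is how an amide or a carboxylic acid would read in place of the ester.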